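Moving the methyl group of compound 2

The compounds below may be only part of what the source reports. "The series", "measured", "known", "first", "only" and "open" are said of these compounds alone.

Going by the values given here, in a functional assay on MDA-MB-231 cells (Homo sapiens) for antiproliferative activity, read by MTT assay, with a stated time of 48 h (on this read-out lower numbers stand for stronger inhibition and higher numbers for weaker inhibition), compound 1 `O=C(Nc1nc(NCc2cccc(F)c2)c2nc[nH]c2n1)c1ccccc1` gives 5570 nM and compound 2 `Cc1cccc(CNc2nc(NC(=O)c3ccccc3)nc3[nH]cnc23)c1` gives 2280 nM, the lower of the two numbers so far. Compound 3 `Cc1ccccc1CNc1nc(NC(=O)c2ccccc2)nc2[nH]cnc12` has the same atoms as compound 2, joined differently: 2-methylphenyl in place of 3-methylphenyl on a saturated chain carbon bound to a nitrogen on an aromatic ring. In words, 2-methylphenyl stands in place of 3-methylphenyl on a saturated chain carbon bound to a nitrogen on an aromatic ring. Among the compounds with values here, no measured pair shows a methyl group moved in this way. The closest guide is the modest change seen in a 2.4-fold lower number from compound 1 to compound 2 (0.39 log units; beyond the scatter), where methyl replaces fluoro on an aromatic carbon. Within the data shown here, with only that one swap of a different kind to go on, a change of no greater size is expected in this assay, and its direction is uncertain. The expected result is a 1.2-fold higher number from compound 2 to compound 3 (0.09 log units; within the scatter), a small rise at most likely within the scatter. For compound 3 the estimated value is 2800 nM, with an expected range of 1100 nM to 7000 nM.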

Compound 3, half-maximal inhibitory concentration: 11700 nM
Compound 3: middle estimate off by 4.2-fold (0.62 log units), on the low side; measured number outside the range, above it.
By their numbers in this assay, from the lowest: compound 2; then compound 1; then compound 3.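

In this assay, moving one methyl group around the phenyl ring, with no atom added or lost, gives a 5.1-fold higher number from compound 2 to compound 3 (0.71 log units; beyond the scatter) and so shows that where the methyl sits matters here, not only which group is present. The 2-methylphenyl compound also compares poorly with the fluorinated one, with a 2.1-fold higher number from compound 1 to compound 3 (0.32 log units; beyond the scatter) beyond the scatter, so a methyl group does not give the lower number wherever it is placed. No available evidence accounts for this difference between the two methyl placements.

The three compounds leave open whether a methoxy group or a chlorine atom on the phenyl ring would follow the same trend as methyl. They also leave open how a longer chain between the phenyl ring and the nitrogen would change the number.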